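This account rests on a few compounds, and the source may have more. Where it says the series, first, only, none or still open, it means among the compounds named here.

Compound 1 `CC1(/C=C/c2ccccc2)C=CC(=O)O1` gives 123000 nM in a functional assay on HT-29 cells (Homo sapiens) for inhibition, read by sulforhodamine B assay, with a stated time of 48 h; a lower number here means a stronger inhibitor of growth, a higher number a weaker inhibitor of growth; compound 2 `CC1(/C=C/c2ccc(O)cc2)C=CC(=O)O1` gives 122000 nM.

Compound 1 stands highest of the two numbers, with compound 2 nearest at a 1.0-fold lower number from compound 1 to compound 2 (0.00 log units; within the scatter). Compound 3 `COc1cccc(/C=C/C2(C)C=CC(=O)O2)c1` differs from compound 1 by methoxy in place of hydrogen on an aromatic carbon. Among the compounds with values here, the only step with bearing is the one on the same ring from compound 1 to compound 2, where hydroxy in place of hydrogen changed nothing beyond the scatter. The methoxy in compound 3 enters at a different place on that ring, so its step is expected to be small, a 1.1-fold lower number from compound 1 to compound 3 (0.05 log units; within the scatter), with no clear direction. Compound 3 is therefore estimated at 110000 nM, in the range 50000 nM to 250000 nM.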

Compound 3, concentration for total growth inhibition: 17000 nM
Compound 3: the middle estimate sits 6.5-fold (0.81 log units) above what was measured; the whole stated range lies above it.
By their numbers in this assay, from the lowest: compound 3; then compounds 2 and 1 (each within the scatter of the next).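

In this assay methoxy in place of hydrogen, on an aromatic carbon meta to a group of 9 heavy atoms, gives a 7.2-fold lower number from compound 1 to compound 3 (0.86 log units; beyond the scatter) and so shows that substitution on this ring can move the number. Hydroxy in compound 2 had not shown this, with a 1.0-fold lower number from compound 1 to compound 2 (0.00 log units; within the scatter) as its step. No measured evidence bears on the reason for the step.

The compounds shown leave open whether the lower number follows this position or the methoxy group itself. Hydroxy, ethoxy or an amine at this same place would help separate the two.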